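Methylsulfonamide for Phenylsulfonamide in an Apolipoprotein B-100 Series

The compounds below may be only part of what the source reports. "The series", "measured", "known", "first", "only" and "open" are said of these compounds alone.

Compound 1 `Cc1cccc(C(=O)Nc2ccc3c(c2)CC(NS(=O)(=O)c2ccccc2)C3)c1-c1ccc(C#N)cc1` gives 5.5 nM in an assay for inhibition of apolipoprotein B-100 (Homo sapiens), tested at 100 nM; a lower number here means a stronger inhibitor, a higher number a weaker inhibitor.
Compound 2 `Cc1cccc(C(=O)Nc2ccc3c(c2)CC(NS(=O)(=O)c2ccccc2)C3)c1-c1ccc(Cl)cc1` gives 2.4 nM in this assay.

Among the measured compounds shown here, compound 2 holds the lowest of the two numbers so far; its only neighbour is compound 1, and the step of a 2.3-fold lower number from compound 1 to compound 2 (0.36 log units; beyond the scatter) places the two apart by more than the scatter. Compound 3 `Cc1cccc(C(=O)Nc2ccc3c(c2)CC(NS(C)(=O)=O)C3)c1-c1ccc(Cl)cc1` differs from compound 2 in one place: methyl in place of phenyl on a sulfonyl sulfur. For the measured compounds named here, no measured step touches the sulfonyl group. Going by the values given here, the single measured step, a 2.3-fold lower number from compound 1 to compound 2 (0.36 log units; beyond the scatter), concerns the substituent on the distal aromatic ring and therefore says little about this change. Without a precedent, the account can only note that a whole ring is exchanged for a single carbon at the sulfonyl sulfur, and such exchanges seldom leave the number untouched. The step is expected to be a 3.3-fold higher number from compound 2 to compound 3 (0.52 log units; beyond the scatter), with the direction uncertain. Compound 3 is estimated at 8 nM, with a range from 2 nM to 40 nM.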

Compound 3, half-maximal inhibitory concentration: 6.6 nM
Estimate against measurement, compound 3: 1.2-fold (0.08 log units) above, within the range that was stated.
By their numbers in this assay, from the lowest: compound 2; then compounds 1 and 3 (each within the scatter of the next).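

At the sulfonyl sulfur, methyl in place of phenyl gives a 2.8-fold higher number from compound 2 to compound 3 (0.44 log units; beyond the scatter) in this assay, so this position now has a measured step of its own, and for this pair its direction is upward. The step is modest, and compound 3 still gives 6.6 nM with a single carbon in place of the whole ring, so inhibition in this series does not depend on the phenyl group at this place. The data available offer no explanation for the size or direction of this step.

From the compounds shown here alone, how an ethyl group, a longer chain or a benzyl group on the sulfonyl sulfur would compare with phenyl and methyl remains open. Going by these compounds, whether the same exchange would give a step of similar size with cyano in place of chloro also remains open.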